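Terminal hydroxy on the long chain of compound 1

This account rests on a few compounds, and the source may have more. Where it says the series, first, only, none or still open, it means among the compounds named here.

Measured compounds:
Compound 1, `CCCCCCCCCCCS(=O)(=O)/C=C/c1ccc(O)c(O)c1`, 11400 nM
Compound 2, `O=S(=O)(/C=C/c1ccc(O)c(O)c1)CCCC1CCCC1`, 6300 nM

The read-out is a functional assay, read by fluorescence and spectrophotometry, with a stated time of 1 h; on this read-out lower numbers stand for an effect already at smaller amounts and higher numbers for an effect only at larger amounts of compound. In this assay compound 1 gives 11400 nM, the highest of the two numbers; its nearest neighbour, compound 2, gives 6300 nM, and the two lie within the scatter of each other, so no order between them can be claimed.

Among the measured compounds shown here, the only measured step, a 1.8-fold lower number from compound 1 to compound 2 (0.26 log units; within the scatter), alters the chain three bonds from the sulfonyl sulfur. Compound 3, `O=S(=O)(/C=C/c1ccc(O)c(O)c1)CCCCCCCCCCCO`, is not yet measured. It differs from compound 1 by hydroxy in place of hydrogen on a saturated chain carbon, ten or more bonds along the chain from a sulfonyl sulfur. For the measured compounds named here, no measured step touches this far end of the chain, so the step from compound 1 to compound 2 bears on it only loosely: it shows that the chain end tolerates a change without a shift beyond the scatter. On that basis the expected step is small, a 1.1-fold higher number from compound 1 to compound 3 (0.02 log units; within the scatter), with no clear direction beyond the scatter. Compound 3 is therefore estimated at 12000 nM, in the range 4000 nM to 36000 nM.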

Compound 3, half-maximal effective concentration: 22600 nM
Estimate against measurement, compound 3: 1.9-fold (0.27 log units) below; the measured number falls inside the stated range.
By their numbers in this assay, from the lowest: compounds 2, 1 and 3 (each within the scatter of the next, the first and the last beyond it).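

In this assay, among the compounds shown here, the step of hydroxy in place of hydrogen on a saturated chain carbon, ten or more bonds along the chain from a sulfonyl sulfur, is a 2.0-fold higher number from compound 1 to compound 3 (0.30 log units; within the scatter) and is the first measured change at this far end of the long chain. It shows that one hydrogen-bond donor and acceptor can be placed here, in the form of a single oxygen, without a shift that can be told apart from the scatter, although the step reaches the edge of that scatter and gives no firm direction. Nothing measured here accounts for the size of this step.

Going by these compounds, whether a carboxylic acid, an amine or a methoxy group at this place would read differently in this assay stays open, so one hydroxy cannot yet be taken as standing for other groups at the chain end. On these data alone, it is equally open whether a shorter chain carrying the same hydroxy would behave as the long chain of compound 3 does, since all that is known at this place comes from a single step.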